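Extending the Chain End of Compound 2

The compounds below may be only part of what the source reports. "The series", "measured", "known", "first", "only" and "open" are said of these compounds alone.

Compound 1 `COc1ccc2[nH]cc(C(=O)NCC3CCNCC3)c2c1`: 42%
Compound 2 `CCCCCN1CCC(NC(=O)c2cc(Cl)c(N)cc2OC)CC1`: > 100%
Compound 3 `COc1cc(N)c(Cl)cc1C(=O)NC1CCN(CCN2C(=O)c3ccccc3C2=O)CC1`: 94%

All three were tested in a functional assay on HEK293 cells for activation of 5-hydroxytryptamine receptor 4 (Homo sapiens), read by cAMP accumulation; a higher number here means a larger maximal response, a lower number a smaller maximal response. Compound 2 is the one whose result is a limit of the assay rather than a number: the limit of > 100% in this assay, at which 1 of the 3 values shown sits. Going by the values given here, no two measured compounds differ in a single place, so no measured step shows how one change alone moves the read-out. Compound 4 `COc1cc(N)c(Cl)cc1C(=O)NC1CCN(CCCCCN2C(=O)c3ccccc3C2=O)CC1` is compound 2 with a group of 11 heavy atoms (8 carbon, 1 nitrogen, 2 oxygen; one five-membered non-aromatic ring with 1 hetero atom, one six-membered aromatic ring of carbon only) in place of a hydrogen atom, on a saturated chain carbon, five bonds along the chain from an amine nitrogen in a ring. Compound 3 carries the same shared core and in this assay compound 3 gives 94%. Compound 4 is expected to give about 95%, between 75% and 110%. The step from compound 2 to compound 4 is estimated at a number at least 5 percentage points lower from compound 2 to compound 4 (that floor lies within the scatter), not clearly beyond the scatter.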

Compound 4, intrinsic activity: the largest response reached, in percent of the reference agonist's: > 100%
Compound 4: only a limit was reported; the forecaster's own chance of this, stated with the estimate: 30%; middle value at least 5 percentage points away from the limit.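

Compound 2 and compound 4 both sit at a limit rather than at a number, so no step between them can be read: the limit of > 100% in this assay, at which 2 of the 4 values shown sit.

The compounds shown leave open whether the added group changes the maximal response at all.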